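This account rests on a few compounds, and the source may have more. Where it says the series, first, only, none or still open, it means among the compounds named here.

Measured in a functional assay on Jurkat cells (Homo sapiens); on this read-out lower numbers stand for stronger inhibition and higher numbers for weaker inhibition:
- compound 1 `CC(C)[C@H](NC(=O)COc1cccc2ccccc12)C(=O)N[C@@H](CC(=O)O)C(=O)COc1cccc(C(F)(F)F)c1`: > 100000 nM, a limit of the assay
- compound 2 `CC(C)[C@H](NC(=O)COc1cccc2ccccc12)C(=O)N[C@@H](CC(=O)O)C(=O)COc1ccc(OC(F)(F)F)cc1`: 29100 nM
- compound 3 `CC(C)[C@H](NC(=O)COc1cccc2ccccc12)C(=O)N[C@@H](CC(=O)O)C(=O)COc1c(F)c(F)cc(F)c1F`: 4500 nM

Compound 3 holds the lowest number of the three, and the nearest measured step is a 6.5-fold lower number from compound 2 to compound 3 (0.81 log units; beyond the scatter). Compound 4 `CC(C)[C@H](NC(=O)COc1cccc2ccccc12)C(=O)N[C@@H](CC(=O)O)C(=O)COc1cccc(C(F)(F)F)c1F` carries 2-fluoro-3-(trifluoromethyl)phenyl in place of 2,3,5,6-tetrafluorophenyl on an oxygen on a saturated carbon. For the measured compounds named here, the closest precedent is an at least 22-fold lower number from compound 1 to compound 3 (1.34 log units; beyond the scatter), a large step that replaces 3-(trifluoromethyl)phenyl, a group that compound 4 largely retains. Its size rests on a limit: the limit of > 100000 nM in this assay, at which 1 of the 3 values shown sits. A modest to large rise in the number is therefore expected, with the added 2-fluoro possibly softening it. The expected step is a 4.9-fold higher number from compound 3 to compound 4 (0.69 log units; beyond the scatter). For compound 4 the estimated value is 22000 nM, within an expected range of 5000 nM to 100000 nM.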

Compound 4, half-maximal inhibitory concentration: 50400 nM
Estimate against measurement, compound 4: 2.3-fold (0.36 log units) below; measured number inside the range.
By their numbers in this assay, from the lowest: compound 3; then compounds 2 and 4 (each within the scatter of the next). At a limit, above all of these: compound 1.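

Replacing 2,3,5,6-tetrafluorophenyl with 2-fluoro-3-(trifluoromethyl)phenyl on this oxygen is costly in this assay, with an 11-fold higher number from compound 3 to compound 4 (1.05 log units; beyond the scatter). The new group cannot be told apart from 4-(trifluoromethoxy)phenyl, with a 1.7-fold higher number from compound 2 to compound 4 (0.24 log units; within the scatter). Fluoro in place of hydrogen on the 3-(trifluoromethyl)phenyl group gives an at least 1.9-fold lower number from compound 1 to compound 4 (0.29 log units; that floor lies within the scatter), and its true size stays unresolved because compound 1 stands at a limit: the limit of > 100000 nM in this assay, at which 1 of the 4 values shown sits.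

Which of the fluoro substituents of compound 3 carry its lower number remains open. So does how a plain phenyl, or a phenyl bearing a nitrile or a methoxy group, would read here.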